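Aryl halogen swap: chloro returns at a different position

The source may hold more compounds than are shown below. What is called first, only, known or untested is meant among the compounds shown, and "the series" means these compounds.

Compound 1 `O=C1c2ccccc2S(=O)(=O)N1CCCCCCN1CCN(c2ccccc2Cl)CC1` gives 120 nM in an ADME assay on HEK293 cells for displacement of a labelled ligand from 5-hydroxytryptamine receptor 7 (Homo sapiens), read by radioligand binding, with a stated time of 1 h (a higher number here means a weaker inhibitor, a lower number a stronger inhibitor), while compound 2 `O=C1c2ccccc2S(=O)(=O)N1CCCCCCN1CCN(c2ccccc2F)CC1` gives 322 nM in this assay; the change between them is a 2.7-fold higher number from compound 1 to compound 2 (0.43 log units; beyond the scatter). Compound 2 therefore holds the highest of the two numbers seen so far. Compound 3 `O=C1c2ccccc2S(=O)(=O)N1CCCCCCN1CCN(c2cccc(Cl)c2)CC1` differs from compound 2 by 3-chlorophenyl in place of 2-fluorophenyl on an amine nitrogen in a ring. Among the measured compounds shown here, only one measured step bears on this, a 2.7-fold higher number from compound 1 to compound 2 (0.43 log units; beyond the scatter), and it is modest; the positional shift of the halogen has no precedent here. A modest lowering is expected, read as a 1.9-fold lower number from compound 2 to compound 3 (0.28 log units; within the scatter). Compound 3 is estimated at 170 nM, with a range of 60 nM to 500 nM.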

Compound 3, inhibition constant: 233 nM
Compound 3: middle estimate off by 1.4-fold (0.14 log units), on the low side, and the stated range covers the measured number.
By their numbers in this assay, from the lowest: compounds 1, 3 and 2 (each within the scatter of the next, the first and the last beyond it).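

Replacing 2-chlorophenyl with 3-chlorophenyl gives a 1.9-fold higher number from compound 1 to compound 3 (0.29 log units; within the scatter), and replacing 2-fluorophenyl with 3-chlorophenyl gives a 1.4-fold lower number from compound 2 to compound 3 (0.14 log units; within the scatter). In this assay, compound 3 therefore cannot be separated from either neighbour, although compound 1 and compound 2 stand apart by a 2.7-fold higher number from compound 1 to compound 2 (0.43 log units; beyond the scatter). No measurement on hand accounts for these values.

Open, going by these compounds, is whether a methoxy group or a nitrile in place of the chlorine would stay within the same narrow span. On these data alone, a shorter chain on the same ring nitrogen also remains untested against these aryl groups.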